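A few compounds are considered here, and "the series" means these few. Any claim that something is new, unique, unknown or untested is made for them only; others in the source may bear on it.

In a functional assay on KB cells (Homo sapiens) for cytotoxicity (a lower number here means a stronger inhibitor, a higher number a weaker inhibitor), compound 1 `O=C(OC1=CC(=O)c2ccccc2C1=O)c1ccccc1` gives 36900 nM and compound 2 `CC(=O)OC1=CC(=O)c2ccccc2C1=O` gives 38800 nM with a difference of a 1.1-fold higher number from compound 1 to compound 2 (0.02 log units; within the scatter) for methyl in place of phenyl on a carbonyl carbon. Compound 3 `CCOC1=CC(=O)c2ccccc2C1=O` gives 16900 nM as the lowest of the three numbers, and it stands beyond the scatter from both others. It is reached by a 2.3-fold lower number from compound 2 to compound 3 (0.36 log units; beyond the scatter) with ethyl in place of acetyl on an oxygen on an unsaturated carbon.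

Compound 4 `O=C1C=C(Oc2ccco2)C(=O)c2ccccc21` carries furan-2-yl in place of ethyl on an oxygen on an unsaturated carbon. Among the compounds with values here, no measured compound has furan-2-yl at that oxygen. The nearest guide is compound 2, whose step of a 2.3-fold lower number from compound 2 to compound 3 (0.36 log units; beyond the scatter) was modest at this same oxygen. Compound 1 adds that a ring swapped for a small group gave only a 1.1-fold higher number from compound 1 to compound 2 (0.02 log units; within the scatter) as a step. The expected step is therefore a 1.3-fold higher number from compound 3 to compound 4 (0.11 log units; within the scatter) and so none beyond the scatter. In this assay compound 4 is estimated at 22000 nM with an expected range from 8000 nM to 50000 nM as its likely span.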

Compound 4, half-maximal inhibitory concentration: 53400 nM
For compound 4 the middle estimate is 2.4-fold (0.39 log units) below the measured one; the whole stated range lies below it.
By their numbers in this assay, from the lowest: compound 3; then compounds 1, 2 and 4 (each within the scatter of the next).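

In this assay, the change from ethoxy to (furan-2-yl)oxy gives a 3.2-fold higher number from compound 3 to compound 4 (0.50 log units; beyond the scatter) and so removes the advantage that ethyl had shown at this oxygen on an unsaturated carbon. Furan-2-yl in place of acetyl gives a 1.4-fold higher number from compound 2 to compound 4 (0.14 log units; within the scatter) and leaves these two groups within the scatter of each other, so a ring at this oxygen matches acetyl and does not match ethyl. Among these three groups, ethyl alone stands apart, with its steps to both others beyond the scatter. Nothing available bears on the reason for this pattern. 

The compounds shown leave open whether a longer chain such as butyl or a chain ending in an amine would keep or extend the result seen with ethyl. They also leave open whether a phenyl ring on this oxygen would behave as furan-2-yl does.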